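Hydroxycarbamoyl replacing the dibromophenol on the thioether arm

The source may hold more compounds than are shown below. What is called first, only, known or untested is meant among the compounds shown, and "the series" means these compounds.

Measured so far in an assay on HEK293 cells for inhibition of solute carrier family 22 member 12 (Homo sapiens); on this read-out higher numbers stand for weaker inhibition and lower numbers for stronger inhibition:
compound 1 `O=C(O)CSc1nnc(Br)n1Cc1ccc(Br)c2ccccc12`: 94 nM
compound 2 `Oc1c(Br)cc(CSc2nnc(Br)n2Cc2ccc(Br)c3ccccc23)cc1Br`: 119000 nM

Compound 2 stands at the highest of the two numbers; its nearest neighbour is compound 1, and the step of a 1300-fold higher number from compound 1 to compound 2 (3.10 log units; beyond the scatter) separates them, so the two values are far apart and the order is beyond doubt on this read-out.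

Compound 3 `O=C(CSc1nnc(Br)n1Cc1ccc(Br)c2ccccc12)NO` is not yet measured. It differs from compound 2 by hydroxycarbamoyl in place of 3,5-dibromo-4-hydroxyphenyl on a saturated chain carbon bound to a sulfur. Among the measured compounds shown here, the change undoes the group that had entered between compound 1 and compound 2 and puts in its place a small acyclic group, so the only step that bears on it is a 1300-fold higher number from compound 1 to compound 2 (3.10 log units; beyond the scatter), which was large and ran upward. Reversing that exchange is therefore expected to carry the number a long way back down, though the hydroxycarbamoyl is not the carboxy of compound 1 and full return to that value is not assumed.

For compound 3 the expected step is a 200-fold lower number from compound 2 to compound 3 (2.30 log units; beyond the scatter), giving an estimate of 600 nM with a range from 100 nM to 4000 nM.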

Compound 3, half-maximal inhibitory concentration: 640 nM
Compound 3: the middle estimate sits 1.1-fold (0.03 log units) below what was measured, and the stated range covers the measured number.
By their numbers in this assay, from the lowest: compound 1; then compound 3; then compound 2.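

In this assay, hydroxycarbamoyl in place of 3,5-dibromo-4-hydroxyphenyl on a saturated chain carbon bound to a sulfur gives a 190-fold lower number from compound 2 to compound 3 (2.27 log units; beyond the scatter), so most of the ground lost with the dibromophenol is regained here without a carboxy group. This position therefore does not depend strictly on carboxy. Carboxy still keeps an edge, since hydroxyamino in place of hydroxy on a carbonyl carbon gives a 6.8-fold higher number from compound 1 to compound 3 (0.83 log units; beyond the scatter), a modest step that lies beyond the scatter and leaves compound 1 with the lowest number of the three. No measurement at hand accounts for either step.

The compounds shown leave open which part of the arm carries the gain, as a primary carboxamide, a methyl ester or a tetrazole at this place would separate the carbonyl from the hydroxyl on the hydroxycarbamoyl. They also leave open whether the ring of the dibromophenol or its bromines go with the high number, which a plain phenyl would test, and how a longer chain carrying the carboxy would read.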